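Dropping the Methoxy Groups: Compound 3 to Compound 4

The source may hold more compounds than are shown below. What is called first, only, known or untested is meant among the compounds shown, and "the series" means these compounds.

Three compounds of a shared core have been measured in an assay on isolated protein for inhibition of RAC-alpha serine/threonine-protein kinase (Homo sapiens), read by fluorescence, with a stated time of 30 min, tested at 10 uM; a higher number here means more inhibition at the concentration tested (going by the name of the read-out), a lower number less inhibition:

Compound 1, `O=C(Nc1cc(Sc2ncn[nH]2)c(O)c2ccccc12)c1ccc([N+](=O)[O-])cc1`, gives 37.3%.
Compound 2, `O=C(Nc1cc(Sc2ncn[nH]2)c(O)c2ccccc12)c1cccc([N+](=O)[O-])c1`, gives 29.3%.
Compound 3, `COc1ccc(/C=C/C(=O)Nc2cc(Sc3ncn[nH]3)c(O)c3ccccc23)cc1OC`, gives 31.7%.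

Compound 3 stands second highest of the three; its number is close to that of compound 2 and to that of compound 1, and all three lie within the scatter of one another. Within the data shown here, the only single-place step measured so far, a number 8 percentage points lower from compound 1 to compound 2 (within the scatter), concerns a shift of the nitro group on the benzamide and does not touch the cinnamamide part.

Compound 4, `O=C(/C=C/c1ccccc1)Nc1cc(Sc2ncn[nH]2)c(O)c2ccccc12`, differs from compound 3 in one place: phenyl in place of 3,4-dimethoxyphenyl on a double-bonded chain carbon bound to a double-bonded chain carbon. Among the measured compounds shown here, no measured step bears on this change directly. Given that every number measured so far on this core falls within the scatter of the others, compound 4 is expected to give 30%, with a range from 15% to 45%. The step of a number 1.7 percentage points lower from compound 3 to compound 4 (within the scatter) is therefore expected to stay within the scatter, with no direction claimed.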

Compound 4, a percentage reported as inhibition, at one concentration (the size of the read-out at that concentration, not a potency): 26.2%
Estimate against measurement, compound 4: 3.8 percentage points above; the measured number falls inside the stated range.
By their numbers in this assay, from the lowest: compounds 4, 2, 3 and 1 (each within the scatter of the next, the first and the last beyond it).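

In this assay, among these compounds, the exchange of 3,4-dimethoxyphenyl for phenyl on a double-bonded chain carbon bound to a double-bonded chain carbon is the first change measured at this position, and it stays within the scatter (a number 5.5 percentage points lower from compound 3 to compound 4 (within the scatter)). Among the compounds shown here, on the carbonyl carbon, 2-phenylethenyl gives the first step beyond the scatter when it replaces 4-nitrophenyl, a modest one (a number 11.1 percentage points lower from compound 1 to compound 4 (beyond the scatter)), but not when it replaces 3-nitrophenyl (a number 3.1 percentage points lower from compound 2 to compound 4 (within the scatter)), so this exchange has no single outcome across the two nitrophenyl groups. Nothing measured here gives a reason for any of these steps.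

Going by these compounds, whether an amine or a carboxylic acid on the phenyl ring would take the number beyond the scatter remains open. So does the effect of a longer chain between the carbonyl carbon and that ring.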